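Propyl in Place of Hydrogen on a Sulfur

This account rests on a few compounds, and the source may have more. Where it says the series, first, only, none or still open, it means among the compounds named here.

Three compounds have been measured in a functional assay on T-24 cells (Homo sapiens) for antiproliferative activity, read by crystal violet staining, with a stated time of 96 h; on this read-out higher numbers stand for an effect only at larger amounts of compound and lower numbers for an effect already at smaller amounts:

compound 1, `O[C@@H]1[C@@H](O)[C@H](Oc2ccc(S)c3ccccc23)OC[C@H]1O`, 55 uM
compound 2, `O[C@@H]1[C@@H](O)[C@H](Oc2cccc3cccc(S)c23)OC[C@H]1O`, 45 uM
compound 3, `CCCSc1ccc(O[C@@H]2OC[C@@H](O)[C@H](O)[C@H]2O)c2ccccc12`, 30 uM

Compound 1 and compound 2 are built from the same atoms joined differently; the difference between the two cores is not broken down here. Compound 3 is compound 1 with a single change, (propyl in place of hydrogen on a sulfur). That change gave a 1.8-fold lower number from compound 1 to compound 3 (0.26 log units; within the scatter). Compound 4, `CCCSc1cccc2cccc(O[C@@H]3OC[C@@H](O)[C@H](O)[C@H]3O)c12`, has not yet been measured. It stands to compound 2 exactly as compound 3 stands to compound 1, namely (propyl in place of hydrogen on a sulfur). The surroundings of the change are the same word for word in both pairs, so this is the same change, not merely the same kind. Going by the values given here, only one measured example of it exists, and its step lies within the scatter, so the expectation rests on a single step applied to the value of compound 2 in this assay. The step to compound 4 is expected to be about a 1.8-fold lower number from compound 2 to compound 4 (0.26 log units; within the scatter), because the same change already gave a 1.8-fold lower number from compound 1 to compound 3 (0.26 log units; within the scatter). On that basis compound 4 is estimated at 25 uM, with the likely range from 12 uM to 50 uM.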

Compound 4, concentration for half-maximal effect: 155 uM
For compound 4 the middle estimate is 6.2-fold (0.79 log units) below the measured one, and the stated range ends below it.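

In this assay, propyl in place of hydrogen on a sulfur gave a 3.4-fold higher number from compound 2 to compound 4 (0.54 log units; beyond the scatter), so on this core the change went the opposite way from what the earlier pair suggested. Set side by side, the two results do not agree, and the change cannot simply be carried from one core to the other in this series: the same change on two cores in this assay, a 1.8-fold lower number (0.26 log units; within the scatter) from compound 1 to compound 3 and a 3.4-fold higher number (0.54 log units; beyond the scatter) from compound 2 to compound 4, 6.3-fold (0.80 log units) apart, beyond the scatter of two such steps. This shows that the outcome of this change depends on the core it is made on, at least for these two pairs, but it does not show why, and two pairs cannot predict what the change would do on a further core.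

On these data alone, the sulfur in these compounds carries only hydrogen or propyl, so it remains open how a methyl group, a longer chain such as hexyl, or a chain ending in an amine or a carboxylic acid would behave on either core. Whether any of these would follow compound 3 or compound 4 is equally unsettled.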